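The compounds below may be only part of what the source reports. "The series", "measured", "known", "first", "only" and "open" are said of these compounds alone.

Measured so far:
compound 1, `CC#CCN(C)Cc1cc2cc(O)ccc2n1C`, 8800 nM;
compound 2, `C#CCN(C)Cc1cc2cc(O)ccc2n1C`, 820 nM;
compound 3, `CCNCc1cn(Cc2ccccc2)c2ccccc12`, 429000 nM.

All three were tested in an assay on isolated protein for inhibition of Amine oxidase [flavin-containing] B (Rattus norvegicus); a higher number here means a weaker inhibitor, a lower number a stronger inhibitor. Compound 2 gives 820 nM, and compound 1 gives 8800 nM, so the change methyl in place of hydrogen on a triple-bonded carbon produced an 11-fold higher number from compound 2 to compound 1 (1.03 log units; beyond the scatter). Compound 3 belongs to a different core, and the difference between the two cores is not broken down here; in this assay compound 3 gives 429000 nM, far above both others.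

Compound 4, `CC(C)NCc1cn(Cc2ccccc2)c2ccccc12`, has not yet been measured. It differs from compound 3 by methyl in place of hydrogen on a saturated chain carbon bound to an amine nitrogen and a saturated chain carbon. Among the measured compounds shown here, this is the same kind of change as the one from compound 2 to compound 1, but the surroundings differ: in compound 1 the new methyl sits on a triple-bonded carbon, whereas in compound 4 it sits on a saturated chain carbon bound to an amine nitrogen and a saturated chain carbon. Because the measured step of an 11-fold higher number from compound 2 to compound 1 (1.03 log units; beyond the scatter) came from a different place and a different core, it gives only a loose guide. The expectation for this assay is a step of a 1.4-fold higher number from compound 3 to compound 4 (0.15 log units; within the scatter), a modest weakening at most. Compound 4 is therefore estimated at 600000 nM, expected to lie between 150000 nM and 2500000 nM.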

Compound 4, inhibition constant: 438000 nM
Compound 4: the middle estimate sits 1.4-fold (0.14 log units) above what was measured; the measured number falls inside the stated range.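

In this assay, putting a methyl in place of a hydrogen on the saturated chain carbon, which turns ethylamino into isopropylamino, gives a 1.0-fold higher number from compound 3 to compound 4 (0.01 log units; within the scatter), so this change makes no measurable difference on the core of compound 3. Set beside the earlier step, the same kind of change does not carry over from one core to the other with the same size: the same change on two cores in this assay, an 11-fold higher number (1.03 log units; beyond the scatter) from compound 2 to compound 1 and a 1.0-fold higher number (0.01 log units; within the scatter) from compound 3 to compound 4, 11-fold (1.02 log units) apart, beyond the scatter of two such steps This does not show what lies behind the gap, as the methyl sits on a triple-bonded carbon in one pair and on a saturated chain carbon in the other, so the effect of the core cannot be told apart from that of the place, and two steps make no general rule.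

Still open, going by these compounds, is how the core of compound 3 would respond to a longer chain, such as butyl, in place of the isopropyl. Also open, on these data alone, is what a carboxylic acid on that chain would do in this assay.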